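Working notes: the step from compound 2 to compound 3

This account rests on a few compounds, and the source may have more. Where it says the series, first, only, none or still open, it means among the compounds named here.

Measured so far:
compound 1 `N#CC1=C(NCC(=O)N2CCOCC2)N(c2ccccc2)C(=O)N2CCCCC(N3CCCC3)C12`: 69.8%
compound 2 `N#CC1=C(/N=C/Nc2ccc([N+](=O)[O-])cc2)N(c2ccccc2)C(=O)N2CCCCC(N3CCCC3)C12`: 41.5%

Within the data shown here, in a functional assay on the whole organism (strain albino) for inhibition, with Rattus norvegicus as the target, read by paw edema, with stated times of 1 h and 2 h, at a dose of 20 mmol/kg by the intraperitoneal route (on this read-out lower numbers stand for less inhibition and higher numbers for more inhibition at the one dose given (going by the name of the read-out)), compound 1 gives 69.8% and compound 2 gives 41.5%, the lower of the two numbers; the single measured step, a number 28.3 percentage points lower from compound 1 to compound 2 (beyond the scatter), separates them. Compound 3 `CCOC(=O)C(=O)NC1=C(C#N)C2C(N3CCCC3)CCCCN2C(=O)N1c1ccccc1` is not yet measured. It differs from compound 2 by a group of 8 heavy atoms (4 carbon, 1 nitrogen, 3 oxygen; no ring) in place of a group of 12 heavy atoms (7 carbon, 3 nitrogen, 2 oxygen; one six-membered aromatic ring of carbon only), on a double-bonded ring carbon. The step that bears on this is a number 28.3 percentage points lower from compound 1 to compound 2 (beyond the scatter), where a group with no aromatic ring was replaced by one carrying such a ring and inhibition fell. Among the measured compounds shown here, compound 3 again removes the aromatic ring, so a rise is expected, a number 13.5 percentage points higher from compound 2 to compound 3 (beyond the scatter); the entering group is not the one present in compound 1, and a smaller step than the measured one is expected. Compound 3 is estimated at 55%, with a range from 40% to 70%.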

Compound 3, a percentage reported as inhibition, in the whole organism at one dose (the size of the read-out at that dose, not a potency): 83.6%
Compound 3: middle estimate off by 28.6 percentage points, on the low side, and the stated range ends below it.
By their numbers in this assay, from the lowest: compound 2; then compound 1; then compound 3.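

At the double-bonded ring carbon, with the shared core unchanged, ((ethoxycarbonyl)carbonyl)amino in this assay gives a number 42.1 percentage points higher from compound 2 to compound 3 (beyond the scatter), so this position can carry inhibition well above what compound 2 showed. The same group also exceeds the morpholine-bearing substituent, with a number 13.8 percentage points higher from compound 1 to compound 3 (beyond the scatter), so groups without an aromatic ring differ clearly among themselves here, and the ring-free group ranks highest of the compounds shown. No measurement at hand accounts for these steps. Still open, from the compounds shown here alone, is how a carboxylic acid or an acetyl group on that amine nitrogen would compare with (ethoxycarbonyl)carbonyl.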